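Oxazoline aryl ethers: acute rat toxicity notes

The compounds below may be only part of what the source reports. "The series", "measured", "known", "first", "only" and "open" are said of these compounds alone.

Measured so far:
compound 1 `COc1ccc(OCC2=NCCO2)cc1` — 5%
compound 2 `Clc1ccc(OCC2=NCCO2)cc1` — 10%

In a toxicity assay on the whole organism with Rattus norvegicus as the target, at a dose of 100 mg/kg by the oral route (a higher number here means a stronger effect of the compound at the dose given, a lower number a weaker effect), compound 1 gives 5% and compound 2 gives 10%. Going by the values given here, compound 2 holds the higher of the two numbers, but the one measured step, a number 5 percentage points higher from compound 1 to compound 2 (within the scatter) with chloro in place of methoxy on an aromatic carbon, lies within the scatter, so the two compounds cannot be told apart on this read-out.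

Compound 3 `Cc1cc(OCC2=NCCO2)ccc1Cl` is not yet measured. It differs from compound 2 as follows: methyl in place of hydrogen on an aromatic carbon.

Among the compounds with values here, no measured step concerns a methyl entering on an aromatic carbon; the only step on record, a number 5 percentage points higher from compound 1 to compound 2 (within the scatter), exchanges one substituent for another and is within the scatter. Nothing in the series therefore points to a shift beyond the scatter in this assay for compound 3, in either direction, and the expectation rests on compound 2 alone at 10%.

The estimated step is a number 2 percentage points higher from compound 2 to compound 3 (within the scatter), expected to stay within the scatter. Compound 3 is estimated at 12%, with a range from 2% to 30%.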

Compound 3, a percentage reported as activity, at one dose (the size of the read-out at that dose, not a potency): 20%
Estimate against measurement, compound 3: 8 percentage points below, and the stated range covers the measured number.
By their numbers in this assay, from the lowest: compounds 1, 2 and 3 (each within the scatter of the next, the first and the last beyond it).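

In this assay, methyl in place of hydrogen on an aromatic carbon, ortho to a chloro group and meta to a group of 7 heavy atoms, gives a number 10 percentage points higher from compound 2 to compound 3 (within the scatter). Going by these compounds alone, this is the first reading at a position that carries only hydrogen in compound 2, and it shows that one added carbon with no hydrogen-bond donors, no hydrogen-bond acceptors and no net charge can be placed there without a step beyond the scatter, whereas the earlier step concerned only the exchange of one substituent for another. No measurement on hand bears on what lies behind this step.

Going by these compounds, whether a larger or different group at this position, such as an ethyl chain, a methoxy group, an amine or a carboxylic acid, would give a step beyond the scatter remains open. Also open, on these data alone, is whether a methyl on this carbon would read the same in a compound with methoxy in place of the chloro group, or at another carbon of the same aromatic ring.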